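Trimming the pyridine substituent: from 4-fluorophenyl to methyl

This account rests on a few compounds, and the source may have more. Where it says the series, first, only, none or still open, it means among the compounds named here.

In a functional assay on HeLa cells (Homo sapiens) for cytotoxicity, read by MTT assay, with a stated time of 48 h (on this read-out higher numbers stand for weaker inhibition and lower numbers for stronger inhibition), compound 1 `COc1cc(-c2cc(COCc3cn(Cc4cc(-c5ccc(F)cc5)cnc4Cl)nn3)on2)cc(OC)c1OC` gives 37300 nM. Among the three compounds with numbers, this value sits at the upper end. Compound 3 `COc1cc(C2CC(COCc3cn(Cc4cc(-c5ccc(F)cc5)cnc4Cl)nn3)ON2C=O)cc(OC)c1OC` gives 27200 nM in this assay, a value that lies within the usual scatter of the number for compound 1, so no order between these two can be drawn. Compound 2 `COc1cc(C2=NOC(COCc3cn(Cc4cc(-c5ccccc5)cnc4Cl)nn3)C2)cc(OC)c1OC` gives 7300 nM in this assay, a lower number that lies beyond the scatter relative to compound 1.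

The step in question goes from compound 1 to compound 4 `COc1cc(-c2cc(COCc3cn(Cc4cc(C)cnc4Cl)nn3)on2)cc(OC)c1OC`, with one change (methyl in place of 4-fluorophenyl on an aromatic carbon). The three measured compounds differ from one another in several places at once, so no single-point comparison among them tells what this particular change does. Among the compounds with values here, the only guidance is that all three numbers are weak in this assay, and that the large aromatic group that leaves is present in compound 1 and compound 3, whose values do not separate beyond the scatter.

The step from compound 1 to compound 4 is therefore expected to be small, most likely no change beyond the scatter or a modest rise in number, as stated by a 1.3-fold higher number from compound 1 to compound 4 (0.13 log units; within the scatter). Compound 4 is estimated at 50000 nM in this assay, with a range from 15000 nM to 150000 nM.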

Compound 4, half-maximal inhibitory concentration: 57700 nM
For compound 4 the middle estimate is 1.2-fold (0.06 log units) below the measured one, within the range that was stated.
By their numbers in this assay, from the lowest: compound 2; then compounds 3, 1 and 4 (each within the scatter of the next, the first and the last beyond it).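

Within the data shown here, the swap of 4-fluorophenyl for methyl gives the first comparison in this set that differs in one place only, and in this assay it comes to a 1.5-fold higher number from compound 1 to compound 4 (0.19 log units; within the scatter). At this aromatic carbon, two atoms from the ring nitrogen and para to a chloro group, the number therefore does not separate from that of compound 1 when a group of 7 heavy atoms with its six-membered aromatic ring gives way to a methyl of 1 heavy atom; the aromatic ring on this carbon is thus not shown to matter for the read-out in this pair, though a single pair sets no pattern. Nothing available gives a reason for this outcome, and no measurement beyond the cell read-out bears on it.

On these data alone, whether an amine, a carboxylic acid or a longer alkyl chain on this same carbon would move the number beyond the scatter remains open. Also open, as far as these compounds go, is whether the same swap would give a similar step on the core of compound 2, whose number is the lowest of the four.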